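Cyano for benzyloxy on the shared aryl-piperazine core

This account rests on a few compounds, and the source may have more. Where it says the series, first, only, none or still open, it means among the compounds named here.

Measured so far:
compound 1 `O=[N+]([O-])c1ccc(N2CCNCC2)cc1NCc1ccccc1`: 28 nM
compound 2 `CN1CCN(c2ccc(OCc3ccccc3)c(NCc3ccco3)c2)CC1`: 402 nM
compound 3 `CC(=O)N(Cc1ccccc1)c1ccc(N2CCN(C)CC2)cc1N`: 164 nM

In an assay on HEK293 cells for displacement of a labelled ligand from 5-hydroxytryptamine receptor 6 (Homo sapiens) (on this read-out higher numbers stand for weaker inhibition and lower numbers for stronger inhibition), compound 2 gives the highest number of the three. Compound 3 stands nearest, with a lower number beyond the scatter; compound 1 lies furthest, with a much lower number. Compound 4 `CN1CCN(c2ccc(C#N)c(NCc3ccco3)c2)CC1` is not yet measured. It differs from compound 2 in one place: cyano in place of benzyloxy on an aromatic carbon. Going by the values given here, no step between measured compounds covers this change, so there is no direct precedent. Still, the cyano of compound 4 stands where compound 1 carries a small group, and in this assay compound 1 gives 28 nM. Compound 4 is expected to follow that direction with a moderate step of a 3.4-fold lower number from compound 2 to compound 4 (0.53 log units; beyond the scatter). Compound 4 is therefore estimated at 120 nM, between 40 nM and 400 nM.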

Compound 4, inhibition constant: 1370 nM
Compound 4: the middle estimate sits 11-fold (1.06 log units) below what was measured; measured number outside the range, above it.
By their numbers in this assay, from the lowest: compound 1; then compound 3; then compound 2; then compound 4.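

In this assay, cyano in place of benzyloxy gives a 3.4-fold higher number from compound 2 to compound 4 (0.53 log units; beyond the scatter) and so weakens inhibition at this position, ortho to the ((furan-2-yl)methyl)amino group and para to the 4-methylpiperazin-1-yl group. Here, losing the benzyloxy group and its six-membered aromatic ring for the smaller cyano group does not strengthen inhibition. No available evidence accounts for this step. Still open, from the compounds shown here alone, is whether methoxy, which keeps the oxygen without the ring, or benzyl, which keeps the ring without the oxygen, would stand nearer compound 2 or compound 4.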